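Swapping the Five-Membered Ring on the Chain Carbon

This account rests on a few compounds, and the source may have more. Where it says the series, first, only, none or still open, it means among the compounds named here.

Of the compounds shown here, three built on one shared core have been tested in a functional assay on CHO cells for antagonist activity at prostaglandin E2 receptor EP3 subtype (Homo sapiens), read by cAMP accumulation; a lower number here means a stronger inhibitor, a higher number a weaker inhibitor. Compound 1 `CC(C)C(c1ccc(-c2ccc3cccc(F)c3c2)[nH]c1=O)N1CCN/C1=N\C#N` gives 38 nM. Compound 2 `CC(C)C(Nc1nccs1)c1ccc(-c2ccc3cccc(F)c3c2)[nH]c1=O` gives 10 nM. Compound 3 `CC(C)C(c1ncc[nH]1)c1ccc(-c2ccc3cccc(F)c3c2)[nH]c1=O` gives 33 nM, the second highest of the three numbers; it sits within the scatter of compound 1, as a 1.2-fold lower number from compound 1 to compound 3 (0.06 log units; within the scatter) shows, while its gap to compound 2, a 3.3-fold higher number from compound 2 to compound 3 (0.52 log units; beyond the scatter), lies beyond it. Compound 4 `CC(C)C(c1noc(=O)[nH]1)c1ccc(-c2ccc3cccc(F)c3c2)[nH]c1=O` has not yet been measured; it differs from compound 3 only in that (a group of 6 heavy atoms (2 carbon, 2 nitrogen, 2 oxygen; one five-membered aromatic ring with 3 hetero atoms) in place of a group of 5 heavy atoms (3 carbon, 2 nitrogen; one five-membered aromatic ring with 2 hetero atoms), on a saturated chain carbon bound to an aromatic carbon and a saturated chain carbon). Among the compounds with values here, the steps that bear on this place are ring exchanges on the same carbon: a 1.2-fold lower number from compound 1 to compound 3 (0.06 log units; within the scatter) left the number essentially unchanged, while a 3.8-fold lower number from compound 1 to compound 2 (0.58 log units; beyond the scatter) and a 3.3-fold higher number from compound 2 to compound 3 (0.52 log units; beyond the scatter) shifted it by modest amounts. Exchanging one small ring for another here has so far produced no more than a modest step, in either direction. For compound 4 the expected step is therefore a 1.1-fold higher number from compound 3 to compound 4 (0.03 log units; within the scatter), small and uncertain in direction. Compound 4 is expected to give about 35 nM, with a likely range from 12 nM to 110 nM.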

Compound 4, half-maximal inhibitory concentration: 41 nM
For compound 4 the middle estimate is 1.2-fold (0.07 log units) below the measured one, within the range that was stated.
By their numbers in this assay, from the lowest: compound 2; then compounds 3, 1 and 4 (each within the scatter of the next).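

In this assay, the ring on this saturated chain carbon can gain oxygen atoms and hydrogen-bond acceptors with no change beyond the scatter (a 1.2-fold higher number from compound 3 to compound 4 (0.09 log units; within the scatter)), and the same holds against the non-aromatic ring of compound 1 (a 1.1-fold higher number from compound 1 to compound 4 (0.03 log units; within the scatter)). The new ring also widens the gap to the thiazolylamino group (a 4.1-fold higher number from compound 2 to compound 4 (0.61 log units; beyond the scatter)), so among these four compounds, compound 2 alone stands apart, with the lowest number, while three quite different groups give numbers within the scatter of one another. Nothing given here explains these numbers.

On these data alone, it remains open whether the lower number of compound 2 belongs to the thiazole ring or to its amino link, which a 1,3-thiazol-2-yl group joined directly to the chain carbon would test. As far as these compounds go, it is also open how a carboxylic acid or a simple amine would behave on the same carbon.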